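The source may hold more compounds than are shown below. What is called first, only, known or untested is meant among the compounds shown, and "the series" means these compounds.

Going by the values given here, compound 1 `O=C(CN1CN(c2ccccc2)C2(CCN(C(=O)c3ccc(C4CCCCC4)cc3)CC2)C1=O)N1CCCCC1` gives 1100 nM in an assay on HEK293 cells for displacement of a labelled ligand from NPC1-like intracellular cholesterol transporter 1 (Homo sapiens) (on this read-out higher numbers stand for weaker inhibition and lower numbers for stronger inhibition), and holds the lowest number of the three compounds measured so far. Compound 2 `CC(C)(C)OC(=O)NC1CCN(C(=O)CN2CN(c3ccccc3)C3(CCN(C(=O)c4ccc(C5CCCCC5)cc4)CC3)C2=O)CC1` gives 4800 nM in this assay, and compound 3 `CC(C)(C)OC(=O)NC1CCCN(C(=O)CN2CN(c3ccccc3)C3(CCN(C(=O)c4ccc(C5CCCCC5)cc4)CC3)C2=O)C1` gives 4400 nM. Each of those two carries a (tert-butoxycarbonyl)amino group in place of hydrogen on a saturated ring carbon, and each step weakens binding beyond the scatter: a 4.4-fold higher number from compound 1 to compound 2 (0.64 log units; beyond the scatter) and a 4.0-fold higher number from compound 1 to compound 3 (0.60 log units; beyond the scatter). Compound 4 `O=C(CN1CN(c2ccccc2)C2(CCN(C(=O)c3ccc(C4CCCCC4)cc3)CC2)C1=O)NCO` differs from compound 1 at another position: (hydroxymethyl)amino in place of piperidin-1-yl on a carbonyl carbon. The two measured steps touch a different part of the shared core, so they speak to the new change only as a general signal that alterations away from the core have each cost a modest amount of binding. Among the compounds with values here, no measured pair shows the exchange of piperidin-1-yl for (hydroxymethyl)amino on a carbonyl carbon, so the direction rests on that signal alone. Compound 4 is therefore expected to show a 2.7-fold higher number from compound 1 to compound 4 (0.44 log units; beyond the scatter), a modest weakening with wide uncertainty. Compound 4 is estimated at 3000 nM, between 900 nM and 10000 nM.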

Compound 4, half-maximal inhibitory concentration: 8300 nM
The estimate for compound 4 lay 2.8-fold (0.44 log units) below the measured number; the range from low to high includes it.
By their numbers in this assay, from the lowest: compound 1; then compounds 3, 2 and 4 (each within the scatter of the next).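

Going by these compounds alone, exchanging the whole piperidin-1-yl ring on the carbonyl carbon for the open-chain (hydroxymethyl)amino group in this assay gives a 7.5-fold higher number from compound 1 to compound 4 (0.88 log units; beyond the scatter) and is the first measured change that removes this ring rather than adding to it. Within the data shown here, compound 1 therefore remains the only compound here with a number beyond the scatter of all the others, and neither keeping the ring with an added group nor replacing it with this smaller group without a ring restores its binding. Nothing available explains the weakening of binding at this position.

The compounds shown leave open whether the loss follows the missing ring or the hydroxymethyl group. Morpholin-4-yl, which keeps a six-membered ring, and plain methylamino, which carries no hydroxyl, would each test one of these separately.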